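Group exchange from compound 1 to compound 3

A few compounds are considered here, and "the series" means these few. Any claim that something is new, unique, unknown or untested is made for them only; others in the source may bear on it.

Measured so far in an ADME assay on microsomes from liver (Homo sapiens) for metabolic stability, with a stated time of 30 min, tested at 1 uM; on this read-out lower numbers stand for a shorter-lived compound and higher numbers for a longer-lived compound
Compound 1 `COc1ccc2[nH]c(C(=O)N3CC(=O)N(Cc4ccccc4)[C@@H](CN4CCC5(CC4)CC5)C3)cc2c1` gives 0.867 h
Compound 2 `COc1cccc(CN2C(=O)CN(C(=O)c3cc4cc(OC)ccc4[nH]3)C[C@@H]2CCc2ccccc2)c1` gives 0.12 h

Compound 1 stands highest of the two measured compounds. Compound 2 lies below it, and the gap between them is beyond the usual scatter of repeated measurements. The next compound to be read in this assay is compound 3 `COc1ccc2[nH]c(C(=O)N3CC(=O)N(Cc4ccccc4)[C@@H](CN4CC5CCCCC5C4)C3)cc2c1`, which keeps the core of compound 1 and changes one group on a saturated chain carbon bound to a saturated ring carbon. The counted difference is a group of 9 heavy atoms (8 carbon, 1 nitrogen; one five-membered non-aromatic ring with 1 hetero atom, one six-membered non-aromatic ring of carbon only) in place of a group of 8 heavy atoms (7 carbon, 1 nitrogen; one three-membered non-aromatic ring of carbon only, one six-membered non-aromatic ring with 1 hetero atom), on a saturated chain carbon bound to a saturated ring carbon and it brings in a five-membered non-aromatic ring with 1 hetero atom.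

Among the measured compounds shown here, compounds 1 and 2 differ in more than one place, so no measured pair shows what this exchange does. For the measured compounds named here, the only anchor is compound 1 at 0.867 h, and a step within the scatter is expected, leaning slightly towards a shorter half-life. The expected change is a 1.6-fold lower number from compound 1 to compound 3 (0.20 log units; within the scatter) and it remains a tentative estimate. For compound 3 the estimated half-life is 0.55 h, with an expected range from 0.2 h to 1.3 h and the measurement still to come.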

Compound 3, half-life: 0.233 h
For compound 3 the middle estimate is 2.4-fold (0.37 log units) above the measured one; low and high end bracket the measured number.
By their numbers in this assay, from the lowest: compounds 2 and 3 (each within the scatter of the next); then compound 1.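

In this assay, among the compounds shown here, this exchange gives the first reading of a single change: a 3.7-fold lower number from compound 1 to compound 3 (0.57 log units; beyond the scatter), which shows that the half-life responds to the group on a saturated chain carbon bound to a saturated ring carbon while the rest of compound 1 stays the same. The groups that leave and enter have the same counts of hydrogen-bond donors and acceptors, and neither carries a net charge, so these counts do not separate compound 1 from compound 3; the groups differ in their ring make-up and heavy-atom count. No measurement at hand gives a reason for the step.

For the compounds shown here, with only one exchange at this place, the effects of losing the three-membered carbon ring and of bringing in the five-membered ring with 1 hetero atom cannot be told apart. Going by these compounds, it also remains open whether a morpholine or a diethylamino group at this place would give a longer or shorter half-life than compound 1 at 0.867 h, and whether any such step would carry over to other groups elsewhere on the shared core.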